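Chloro for methyl on the benzyl group

The source may hold more compounds than are shown below. What is called first, only, known or untested is meant among the compounds shown, and "the series" means these compounds.

Going by the values given here, compound 2 `Cc1ccc(Cn2nnc(-c3cc([N+](=O)[O-])cc([N+](=O)[O-])c3)n2)cc1` is one of only two compounds measured so far in an ADME assay on CHO-K1 cells (Cricetulus griseus) for cytotoxicity, read by MTT assay, with a stated time of 24 h (a lower number here means a stronger inhibitor, a higher number a weaker inhibitor), where compound 2 gives 200000 nM; its nearest neighbour is compound 1 `O=[N+]([O-])c1cc(-c2nnn(Cc3ccccc3)n2)cc([N+](=O)[O-])c1`, which in this assay gives 150000 nM, and the two numbers lie within the scatter of each other. Among the compounds with values here, the single measured step, a 1.3-fold higher number from compound 1 to compound 2 (0.12 log units; within the scatter), stays within the scatter. Compound 3 `O=[N+]([O-])c1cc(-c2nnn(Cc3ccc(Cl)cc3)n2)cc([N+](=O)[O-])c1` differs from compound 2 by chloro in place of methyl on an aromatic carbon, read one bond further out as 4-methylbenzyl to 4-chlorobenzyl. Within the data shown here, no measured step swaps chloro for methyl; the only step available, from compound 1 to compound 2, changed the same place on the benzyl group and did not move the number beyond the scatter. For compound 3 the expected step is no change at the digits printed from compound 2 to compound 3 (within the scatter), none beyond the scatter. Compound 3 is therefore estimated at 200000 nM, with a range from 100000 nM to 400000 nM.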

Compound 3, half-maximal inhibitory concentration: 170000 nM
Beside the measured number, compound 3's estimate is 1.2-fold (0.07 log units) above it, and the stated range covers the measured number.
By their numbers in this assay, from the lowest: compounds 1, 3 and 2 (each within the scatter of the next).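

On the aromatic carbon para to a large group, chloro in place of methyl gives no step beyond the scatter in this assay (a 1.2-fold lower number from compound 2 to compound 3 (0.07 log units; within the scatter)). Chloro in place of hydrogen on the same carbon also stays within the scatter (a 1.1-fold higher number from compound 1 to compound 3 (0.05 log units; within the scatter)), so with all three compounds in hand, hydrogen, methyl and chloro at this position are not told apart by this read-out. No available evidence bears on why these numbers lie so close together.

The compounds shown leave open whether an amine, a carboxylic acid or a longer chain on this carbon would move the number beyond the scatter. They also leave open how far the number depends on the shared core rather than on the benzyl group, since the core is the same in all three compounds.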